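Swapping methylsulfonyl for pentylcarbonyl on compound 2

This account rests on a few compounds, and the source may have more. Where it says the series, first, only, none or still open, it means among the compounds named here.

In a functional assay for inhibition, with Homo sapiens as the target (a higher number here means a weaker inhibitor, a lower number a stronger inhibitor), compound 1 `O=C(O)CCNC(=O)c1ccc2c(c1)C(=O)N(CCC1CCNCC1)C2` gives 27 nM and compound 2 `CS(=O)(=O)N[C@@H](CNC(=O)c1ccc2c(c1)C(=O)N(CCC1CCNCC1)C2)C(=O)O` gives 14 nM as its reading. These two numbers lie within the usual scatter of each other, so compound 2 stands level with compound 1. Compound 3 `CCCCS(=O)(=O)N[C@@H](CNC(=O)c1ccc2c(c1)C(=O)N(CCC1CCNCC1)C2)C(=O)O` reads 14 nM; 9 nM (2 entries) over repeated entries, and the several entries of compound 3 in this assay, 14 nM; 9 nM (2 entries) show how far readings of a single compound can spread.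

Compound 4 `CCCCCC(=O)N[C@@H](CNC(=O)c1ccc2c(c1)C(=O)N(CCC1CCNCC1)C2)C(=O)O` has not yet been measured. The change from compound 2 pentylcarbonyl in place of methylsulfonyl on an amine nitrogen puts pentylcarbonyl in place of methylsulfonyl on an amine nitrogen. Within the data shown here, no measured step makes this exact exchange. The closest is a 1.9-fold lower number from compound 1 to compound 2 (0.29 log units; within the scatter) on gaining the methanesulfonamido group, and that step stays within the scatter. With so little movement on record, no shift beyond the scatter is expected in either direction, so the expected change is a 1.1-fold higher number from compound 2 to compound 4 (0.03 log units; within the scatter) in this assay at most. The estimate for compound 4 is 15 nM within an expected range of 6 nM to 40 nM overall.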

Compound 4, half-maximal inhibitory concentration: 13 nM
The estimate for compound 4 lay 1.2-fold (0.06 log units) above the measured number; measured number inside the range.
By their numbers in this assay, from the lowest: compounds 4, 2 and 1 (each within the scatter of the next, the first and the last beyond it).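

In this assay, the amine nitrogen accepts the larger pentylcarbonyl in place of methylsulfonyl with no change beyond the scatter: a 1.1-fold lower number from compound 2 to compound 4 (0.03 log units; within the scatter). So a sulfonyl link is not needed here, and a carbonyl link with a long chain serves equally well in this assay. Measured against hydrogen on the saturated chain carbon, the (pentylcarbonyl)amino group gives the first step at this place to pass the scatter, a 2.1-fold lower number from compound 1 to compound 4 (0.32 log units; beyond the scatter), but only modestly and only just, and the methanesulfonamido step stayed within it, so the small size of these differences should be kept in view: the several entries of compound 3 in this assay, 14 nM; 9 nM (2 entries)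

The compounds shown leave open whether benzoyl or a much shorter acetyl on the amine nitrogen would read the same. They also leave open what a free amine on that saturated chain carbon would do.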